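The source may report more compounds than this note shows. Statements on the series, on what has been measured and on what is new or still open speak of the compounds shown alone.

Of the compounds shown here, three built on one shared core have been tested in a functional assay on PANC-1 cells (Homo sapiens) for cytotoxicity, read by MTT assay, with a stated time of 72 h; a lower number here means a stronger inhibitor, a higher number a weaker inhibitor. Compound 1 `Cc1ccc(-c2ccc(NC3=CC(=O)c4ncncc4C3=O)cc2F)cc1` gives 4800 nM in this assay. Compound 2 `COC(=O)c1ccc(NC2=CC(=O)c3ncncc3C2=O)cc1` gives 1100 nM, and compound 3 `CC(=O)c1cccc(NC2=CC(=O)c3ncncc3C2=O)c1` gives 900 nM. Among these three numbers, compound 2 holds the second highest. Its nearest neighbour is compound 3, whose number sits within the scatter of repeated measurements of this kind, so the two cannot be told apart. Compound 1 stands furthest away, with a higher number that lies beyond that scatter.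

The next compound in the series is compound 4 `O=C1C(Nc2ccc(CO)cc2)=CC(=O)c2ncncc21`. Compared with compound 2, the change is this: hydroxymethyl in place of methoxycarbonyl on an aromatic carbon. Among the compounds with values here, no pair of measured compounds differs by this single change, so no measured step can guide the expectation, and the three known values give no direct hint about swapping one of these groups for the other. On that basis a modest step is anticipated in this assay, most likely toward a slightly higher number, and possibly not beyond the usual scatter at all. Compound 4 is therefore expected to give about 1800 nM in this assay, within a range from 600 nM to 5000 nM. This estimate implies a step of a 1.6-fold higher number from compound 2 to compound 4 (0.21 log units; within the scatter) that is expected to be small.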

Compound 4, half-maximal inhibitory concentration: 1000 nM
For compound 4 the middle estimate is 1.8-fold (0.26 log units) above the measured one; measured number inside the range.
By their numbers in this assay, from the lowest: compounds 3, 4 and 2 (each within the scatter of the next); then compound 1.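

In this assay, putting hydroxymethyl in place of methoxycarbonyl on an aromatic carbon para to a large group gives a 1.1-fold lower number from compound 2 to compound 4 (0.04 log units; within the scatter), so compound 2 and compound 4 cannot be told apart. Within the data shown here, this is the first comparison between compounds that differ in one place. It shows that at this position, a group of 4 heavy atoms with no hydrogen-bond donor can give way to one of 2 heavy atoms with a hydrogen-bond donor, with no change in the read-out beyond the scatter. Nothing among the data shown explains why the two groups read alike.

On these data alone, whether this position would read the same with other groups, such as an amine, a carboxylic acid or a longer chain, remains open, since this single exchange does not speak for them. Among these compounds, compound 1 and compound 3 are also joined to this pair by no single-place step, so what their own substituents and positions contribute in this assay remains unresolved.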